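The source may report more compounds than this note shows. Statements on the series, on what has been measured and on what is new or still open speak of the compounds shown alone.

Measured compounds in an assay on HeLa cells for displacement of a labelled ligand from 5-hydroxytryptamine receptor 6 (Homo sapiens); a higher number here means a weaker inhibitor, a lower number a stronger inhibitor:
compound 1 `CN1CCC(n2cc(S(=O)(=O)c3ccc(F)cc3)c3cccnc32)C1`, 5 nM
compound 2 `CN1CCC(n2cc(S(=O)(=O)c3ccccc3Cl)c3cccnc32)C1`, 2.2 nM
compound 3 `CN1CCC(n2cc(S(=O)(=O)c3ccc(Cl)cc3)c3cccnc32)C1`, 4.2 nM

Compound 3 stands second highest of the three numbers; the steps leading to it are a 1.2-fold lower number from compound 1 to compound 3 (0.08 log units; within the scatter) and a 1.9-fold higher number from compound 2 to compound 3 (0.28 log units; within the scatter), both within the scatter. Compound 4 `CN1CCCC(n2cc(S(=O)(=O)c3ccc(Cl)cc3)c3cccnc32)C1` is not yet measured and differs from compound 3 by 1-methylpiperidin-3-yl in place of 1-methylpyrrolidin-3-yl on an aromatic nitrogen. Going by the values given here, every measured step so far, a 2.3-fold lower number from compound 1 to compound 2 (0.36 log units; beyond the scatter), a 1.2-fold lower number from compound 1 to compound 3 (0.08 log units; within the scatter) and a 1.9-fold higher number from compound 2 to compound 3 (0.28 log units; within the scatter), concerns the group on the sulfonyl sulfur; none touches the ring on the aromatic nitrogen, so no measured step bears directly on this change. The expectation for this assay is therefore a step of a 1.2-fold higher number from compound 3 to compound 4 (0.08 log units; within the scatter), not beyond the scatter. Compound 4 is thus estimated at 5 nM, with a range of 1.5 nM to 17 nM.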

Compound 4, inhibition constant: 11.5 nM
The estimate for compound 4 lay 2.3-fold (0.36 log units) below the measured number; the measured number falls inside the stated range.
By their numbers in this assay, from the lowest: compounds 2, 3 and 1 (each within the scatter of the next, the first and the last beyond it); then compound 4.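

In this assay, the group on the aromatic nitrogen is now shown to affect the number: the six-membered 1-methylpiperidin-3-yl in place of the five-membered 1-methylpyrrolidin-3-yl gives a 2.7-fold higher number from compound 3 to compound 4 (0.44 log units; beyond the scatter), a modest step beyond the scatter. This is a single pair, read only with 4-chlorophenyl on the sulfonyl sulfur. No measurement here accounts for the step.

As far as these compounds go, it remains open whether the same ring change carries over with 2-chlorophenyl or 4-fluorophenyl on the sulfonyl sulfur. Also open, from the compounds shown here alone, is how an N-unsubstituted pyrrolidine, with a hydrogen in place of the methyl, or an open-chain dimethylaminoethyl group would fare at this position.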